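Swapping trifluoromethyl for chloro on the urea aryl group

The source may hold more compounds than are shown below. What is called first, only, known or untested is meant among the compounds shown, and "the series" means these compounds.

Compound 2 `COc1cc(Cl)cc(-c2nn(-c3cccc(NC(=O)Nc4ccc(Cl)c(C(F)(F)F)c4)c3)cc2-c2ccncc2)c1` stands lowest of the two measured numbers: in a functional assay on HOP-62 cells (Homo sapiens) for inhibition, read by sulforhodamine B assay, with a stated time of 48 h, tested at 1 uM (a higher number here means a weaker effect of the compound at the concentration tested, a lower number a stronger effect), compound 2 gives 84%, while compound 1 `O=C(Nc1cccc(-n2cc(-c3ccncc3)c(-c3cc(O)cc(Cl)c3)n2)c1)Nc1ccc(Cl)c(Cl)c1` gives 97%, a gap beyond the scatter. Compound 3 `COc1cc(Cl)cc(-c2nn(-c3cccc(NC(=O)Nc4ccc(Cl)c(Cl)c4)c3)cc2-c2ccncc2)c1` is not yet measured. It differs from compound 2 in one place: chloro in place of trifluoromethyl on an aromatic carbon. Within the data shown here, no measured pair shows this exchange alone, so its size is unknown; a small step toward a higher number, or none beyond the scatter, is expected, since compound 1 carries the entering group and gives 97%. Compound 3 is estimated at 90%, between 76% and 102%, a step of a number 6 percentage points higher from compound 2 to compound 3 (within the scatter).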

Compound 3, a percentage reported as activity, at one concentration (the size of the read-out at that concentration, not a potency): 91%
The estimate for compound 3 lay 1 percentage points below the measured number; low and high end bracket the measured number.
By their numbers in this assay, from the lowest: compounds 2, 3 and 1 (each within the scatter of the next, the first and the last beyond it).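

In this assay the exchange of trifluoromethyl for chloro, read here alone, gives a number 7 percentage points higher from compound 2 to compound 3 (within the scatter) and so does not separate the two groups at this position on the urea aryl ring. Methyl in place of hydrogen on the oxygen likewise gives a number 6 percentage points lower from compound 1 to compound 3 (within the scatter) on the same 3,4-dichlorophenyl background. Nothing measured here bears on the reason for either step. Going by these compounds, whether an amine or a carboxylic acid at the position of the chloro would move the number beyond the scatter stays open, as does the effect of a longer chain on the oxygen.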